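Moving the Acetyl Group Around the Pendant Phenyl Ring

The source may hold more compounds than are shown below. What is called first, only, known or untested is meant among the compounds shown, and "the series" means these compounds.

Compound 1 `Nc1sc(Br)c(-c2cccc(C(F)(F)F)c2)c1C(=O)c1ccccc1` and compound 2 `CC(=O)c1cccc(-c2sc(N)c(C(=O)c3ccccc3)c2-c2cccc(C(F)(F)F)c2)c1` share a common core and differ in a single place. In a functional assay on CHO-K1 cells for agonist activity at adenosine receptor A1 (Homo sapiens), read by GTPgammaS binding (a higher number here means that more compound is needed for the effect, a lower number that less compound is needed), compound 1 gives > 10 uM, which is a limit of the assay rather than a measured number. In this assay compound 2 gives > 10 uM, also a limit. The step that the two limits leave unreadable from compound 1 to compound 2 therefore has no readable size, since both ends sit at the same boundary: the limit of > 10 uM in this assay, at which 2 of the 2 values shown sit. Compound 2 thus stands at the limit, with no number to place it more precisely.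

Compound 3 `CC(=O)c1ccc(-c2sc(N)c(C(=O)c3ccccc3)c2-c2cccc(C(F)(F)F)c2)cc1` has not yet been measured in this assay. It differs from compound 2 by 4-acetylphenyl in place of 3-acetylphenyl on an aromatic carbon. Within the data shown here, the only measured step, a step that the two limits leave unreadable from compound 1 to compound 2, is unreadable and concerns a different change, so nothing among the measured compounds speaks directly to moving the acetyl group from one position of the pendant phenyl to another. With no readable step to lean on, compound 3 is expected to stay close to where compound 2 stands, most likely again at the limit, so the estimated step that the limit leaves unreadable from compound 2 to compound 3 is essentially none beyond the scatter. The estimate for compound 3 in this assay is 15 uM, with a range from 3 uM to 100 uM.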

Compound 3, concentration for half-maximal effect: > 10 uM
Compound 3 was reported as a limit; the forecaster's own chance of this, stated with the estimate: 75%; the middle value lies beyond the limit too.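

Compound 3, like compound 1 and compound 2, stands at a limit in this assay, so no new step can be read among these three compounds: the limit of > 10 uM in this assay, at which 3 of the 3 values shown sit.

What the compounds shown leave open is whether moving the acetyl group, or replacing the bromo group, changes the concentration needed for the effect at all.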